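The source may report more compounds than this note shows. Statements on the series, on what has been measured and on what is new or still open speak of the compounds shown alone.

Measured so far:
- compound 1, `NC(=O)c1c(NC(=O)c2ccccc2C(F)(F)F)sc2c1CCN(C(=S)Nc1ccccc1Cl)C2`: 46900 nM
- compound 2, `NC(=O)c1c(NC(=O)c2ccccc2Br)sc2c1CCN(C(=S)Nc1ccccc1Br)C2`: 24700 nM

In a functional assay on HeLa cells (Homo sapiens) for antiproliferative activity, with a stated time of 24 h (on this read-out higher numbers stand for weaker inhibition and lower numbers for stronger inhibition), compound 2 gives 24700 nM, the lower of the two numbers in hand. Its nearest neighbour is compound 1, which in this assay gives 46900 nM; the two values sit within the scatter of each other, so no order between them is read. Both compounds are weak on this read-out.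

Compound 3, `NC(=O)c1c(NC(=O)c2ccccc2C(F)(F)F)sc2c1CCN(C(=S)Nc1ccccc1Br)C2`, is not yet measured. Relative to compound 2 the change is trifluoromethyl in place of bromo on an aromatic carbon, the substituent sitting ortho to a large group; the same substitution seen from one bond further out reads 2-bromophenyl to 2-(trifluoromethyl)phenyl. Among the measured compounds shown here, no measured pair shows this change on its own, so no step size can be drawn from the data; with both known values weak and close, the expected step is none beyond the scatter. Compound 3 is thus estimated at 33000 nM, with a range of 14000 nM to 80000 nM, which means an expected step of a 1.3-fold higher number from compound 2 to compound 3 (0.13 log units; within the scatter).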

Compound 3, half-maximal inhibitory concentration: > 50000 nM
Compound 3 ended at the assay's limit; the forecaster's own chance of this, stated with the estimate: 15%; middle value at least 1.5-fold (0.18 log units) away from the limit.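

In this assay compound 3 gives > 50000 nM, which is a limit of the assay and not a number. This gives the series its first single-place comparisons: trifluoromethyl in place of bromo, on an aromatic carbon ortho to a large group, gives an at least 2.0-fold higher number from compound 2 to compound 3 (0.30 log units; that floor lies within the scatter), and bromo in place of chloro on an aromatic carbon gives an at least 1.0-fold higher number from compound 1 to compound 3 (0.02 log units; that floor lies within the scatter), both floors within the scatter, so neither change is shown to have any effect. The true size of both steps stays unread because of the ceiling of the read-out: the limit of > 50000 nM in this assay, at which 1 of the 3 values shown sits.

From the compounds shown here alone, whether an amine or a carboxylic acid on that aromatic carbon would give a number clear of the limit remains open. Also open, going by these compounds, is whether any change on the shared core moves the series out of this weak range.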